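This account rests on a few compounds, and the source may have more. Where it says the series, first, only, none or still open, it means among the compounds named here.

Compound 1 `COc1cc(-c2cc(/C=C/C(=O)c3ccc(N)cc3)[nH]n2)cc(OC)c1OC` in a functional assay on Malme-3M cells (Homo sapiens) for cytotoxicity, read by sulforhodamine B assay, with a stated time of 48 h, tested at 1 uM (on this read-out lower numbers stand for a stronger effect and higher numbers for a weaker effect at the one concentration tested), gives 93%, a weak effect at the single concentration. Compound 2 `COc1ccc(-c2cc(/C=C/C(=O)c3cc(OC)c(OC)c(OC)c3)[nH]n2)cc1OC` in this assay gives 93%, level with compound 1 at the digits shown, within the scatter. Compound 3 `COc1ccc(C(=O)/C=C/c2cc(-c3cc(OC)c(OC)c(OC)c3)n[nH]2)cc1OC` is not yet measured in this assay. From compound 1 to compound 3 the change is 3,4-dimethoxyphenyl in place of 4-aminophenyl on a carbonyl carbon. Going by the values given here, no step between measured compounds bears on this change; the two values so far sit at the weak end and show no movement. The expected step from compound 1 to compound 3 in this assay is a number 1 percentage points lower from compound 1 to compound 3 (within the scatter), none beyond the scatter. Compound 3 is estimated at 92%, between 80% and 100%.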

Compound 3, a percentage reported as activity, at one concentration (the size of the read-out at that concentration, not a potency): 106%
For compound 3 the middle estimate is 14 percentage points below the measured one; the whole stated range lies below it.
By their numbers in this assay, from the lowest: compounds 1 and 2 (each within the scatter of the next); then compound 3.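

In this assay, 3,4-dimethoxyphenyl in place of 4-aminophenyl on a carbonyl carbon gives a number 13 percentage points higher from compound 1 to compound 3 (beyond the scatter), so the read-out at this position does respond to the group carried there, and it moves towards a weaker effect. Going by these compounds alone, this is the only step so far, and it rests on a single pair. No measurement on these compounds accounts for the shift. Still open, on these data alone, is whether a plain phenyl or a 4-hydroxyphenyl at this position would read like compound 1 or like compound 3.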